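This account rests on a few compounds, and the source may have more. Where it says the series, first, only, none or still open, it means among the compounds named here.

Measured in a functional assay on ECa-109 cells for inhibition, with ECa-109 cell line (Homo sapiens) as the target, read by sulforhodamine B assay; a higher number here means a weaker inhibitor, a lower number a stronger inhibitor:
- Compound 1 `O=C1C=C(Nc2ccccc2)C(=O)c2c1nc1n2[C@H]2OC[C@@H](O)[C@H]2OC1`: 4970 nM
- Compound 2 `O=C1C=C(N2CCCCC2)C(=O)c2c1nc1n2[C@H]2OC[C@@H](O)[C@H]2OC1`: > 8000 nM (a limit of the assay, not a number)
- Compound 3 `COc1cccc(NC2=CC(=O)c3nc4n(c3C2=O)[C@H]2OC[C@@H](O)[C@H]2OC4)c1`: 7620 nM

Compound 3, at 7620 nM, stands within the scatter of compound 1, with a 1.5-fold higher number from compound 1 to compound 3 (0.19 log units; within the scatter). The value of compound 2 is only a limit, so it cannot be placed exactly.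

Compound 4 `O=C1C=C(N2CCCC2)C(=O)c2c1nc1n2[C@H]2OC[C@@H](O)[C@H]2OC1` is still unmeasured. It has pyrrolidin-1-yl in place of (3-methoxyphenyl)amino on a double-bonded ring carbon.

Two measured steps exchange an aromatic amino group and a saturated ring amine at this carbon: an at least 1.6-fold higher number from compound 1 to compound 2 (0.20 log units; that floor lies within the scatter) and an at least 1.0-fold lower number from compound 2 to compound 3 (0.02 log units; that floor lies within the scatter). On these data alone, both are floors within the scatter, so the true size of each remains open. On this evidence, no step beyond the scatter is expected in this assay, and no direction can be favoured.

The expected step is a 1.0-fold lower number from compound 3 to compound 4 (0.01 log units; within the scatter). For compound 4 the estimated value is 7500 nM, with an expected range of 3500 nM to 16000 nM.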

Compound 4, half-maximal inhibitory concentration: > 16000 nM
Compound 4: no number, only a limit; the forecaster's own chance of this, stated with the estimate: 40%; middle value at least 2.1-fold (0.32 log units) away from the limit.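

In this assay, the exchange at this double-bonded ring carbon now gives steps beyond the scatter, an at least 2.0-fold higher number from compound 3 to compound 4 (0.32 log units; beyond the scatter) and an at least 3.2-fold higher number from compound 1 to compound 4 (0.50 log units; beyond the scatter), whereas the earlier exchanges there gave only floors within it. For compound 4 the reading is a limit of the assay and not a number: the limit of > 16000 nM in this assay, at which 1 of the 4 values shown sits. The step between compound 2 and compound 4 cannot be read, so pyrrolidin-1-yl and piperidin-1-yl remain unordered.

On these data alone, how far compound 4 lies past its limit stays open, and with it the full size of both steps. Also open, as far as these compounds go, is whether an open-chain amine such as dimethylamino, or a morpholin-4-yl ring, on this carbon would read like pyrrolidin-1-yl or like the anilino group of compound 1.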